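This account rests on a few compounds, and the source may have more. Where it says the series, first, only, none or still open, it means among the compounds named here.

For the measured compounds named here, compound 1 `CCOC(=O)/C=C1/SC(N2N=C(c3cc4ccccc4o3)CC2c2ccc(F)cc2)=NC1=O` gives 0.93 ug/mL in a functional assay on A549 cells (Homo sapiens) for antiproliferative activity, read by MTT assay, with a stated time of 96 h (on this read-out higher numbers stand for weaker inhibition and lower numbers for stronger inhibition), the lowest of the two numbers so far. Going by the values given here, compound 2 `CCOC(=O)/C=C1/SC(N2N=C(c3cc4ccccc4o3)CC2c2ccc(OC)c(OC)c2)=NC1=O` gives 3.42 ug/mL in this assay; the one measured step, a 3.7-fold higher number from compound 1 to compound 2 (0.57 log units; beyond the scatter), concerns the substituent on a saturated ring carbon. Compound 3 `COC(=O)/C=C1/SC(N2N=C(c3cc4ccccc4o3)CC2c2ccc(F)cc2)=NC1=O` differs from compound 1 elsewhere: hydrogen in place of methyl on a saturated chain carbon bound to an oxygen next to a carbonyl group. Among the compounds with values here, no measured step touches this position, so nothing speaks for a shift, and the step from compound 1 to compound 3 is expected to lie within the scatter, a 1.1-fold higher number from compound 1 to compound 3 (0.03 log units; within the scatter). Compound 3 is therefore estimated at 1 ug/mL, with a range of 0.5 ug/mL to 2.2 ug/mL.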

Compound 3, half-maximal inhibitory concentration: 0.808 ug/mL
Compound 3: the middle estimate sits 1.2-fold (0.09 log units) above what was measured, and the stated range covers the measured number.
By their numbers in this assay, from the lowest: compounds 3 and 1 (each within the scatter of the next); then compound 2.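

Ethoxycarbonyl to methoxycarbonyl on the core of compound 1 gives, in this assay, a 1.2-fold lower number from compound 1 to compound 3 (0.06 log units; within the scatter), so removing this one carbon from the chain leaves the read-out unchanged within the scatter. For the compounds shown here, this is the first reading at this position, and it holds only for the 4-fluorophenyl compounds. No supporting data bear on why the position behaves this way. Still open, on these data alone, is how a carboxylic acid, an amide or a longer chain such as butoxycarbonyl would read here. Also open, as far as these compounds go, is whether the same holds alongside the 3,4-dimethoxyphenyl group of compound 2.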